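A few compounds are considered here, and "the series" means these few. Any claim that something is new, unique, unknown or untested is made for them only; others in the source may bear on it.

Working notes on the series. Going by the values given here, in a functional assay on MCF7 cells (Homo sapiens) for inhibition, read by MTT assay (a higher number here means a weaker inhibitor, a lower number a stronger inhibitor), compound 1 `COc1cc2ncnc(Nc3ccc(NC(=O)c4cccc(F)c4)cc3)c2cc1OC` gives 13600 nM and compound 2 `COc1cc2ncnc(Nc3ccc(NC(=O)c4ccccc4I)cc3)c2cc1OC` gives 37000 nM, the higher of the two numbers so far. Among the compounds with values here, the only measured step is a 2.7-fold higher number from compound 1 to compound 2 (0.43 log units; beyond the scatter), which is modest and beyond the scatter. It changes both the halogen and the place of substitution, so it does not isolate the position of the iodine.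

Compound 3 `COc1cc2ncnc(Nc3ccc(NC(=O)c4ccc(I)cc4)cc3)c2cc1OC` has the same atoms as compound 2, joined differently: 4-iodophenyl in place of 2-iodophenyl on a carbonyl carbon. It carries 4-iodophenyl in place of 2-iodophenyl on a carbonyl carbon. Within the data shown here, no measured pair tests this change alone. With compound 2 at 37000 nM as the upper of only two reference points, a small step towards a lower number is expected, no larger than the modest step measured so far, and it may stay within the scatter. The expected step is a 1.7-fold lower number from compound 2 to compound 3 (0.23 log units; within the scatter). For compound 3 the estimated value is 22000 nM, with an expected range of 9000 nM to 50000 nM.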

Compound 3, half-maximal inhibitory concentration: 48000 nM
Compound 3: middle estimate off by 2.2-fold (0.34 log units), on the low side; the measured number falls inside the stated range.
By their numbers in this assay, from the lowest: compound 1; then compounds 2 and 3 (each within the scatter of the next).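

Moving the iodine, with 4-iodophenyl in place of 2-iodophenyl on a carbonyl carbon, gives a step within the scatter in this assay (a 1.3-fold higher number from compound 2 to compound 3 (0.11 log units; within the scatter)). This pair keeps the halogen fixed, and between these two iodophenyl groups it shows no readable effect of where the iodine sits. Compound 1 remains apart from compound 3 by a step beyond the scatter (a 3.5-fold higher number from compound 1 to compound 3 (0.55 log units; beyond the scatter)), but that step changes the halogen and its place together, and no measurement on hand offers an explanation for either step.

The compounds shown leave open whether the gap between compound 1 and the two iodophenyl compounds follows the halogen or its place. They also leave open whether an amine or a carboxylic acid in place of the iodine would shift the number.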